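A Urea-Type Change on a Shared Core

This account rests on a few compounds, and the source may have more. Where it says the series, first, only, none or still open, it means among the compounds named here.

Of the compounds shown here, three built on one shared core have been measured in a functional assay on IGROV-1 cells (Homo sapiens) for inhibition, read by sulforhodamine B assay, with a stated time of 48 h; on this read-out lower numbers stand for stronger inhibition of growth and higher numbers for weaker inhibition of growth. Compound 1 `O=C(Nc1cccc(-n2cc(-c3ccncc3)c(-c3ccc(Cl)c(O)c3)n2)c1)Nc1ccc(Cl)c(Cl)c1` gives 1770 nM. Compound 3 `O=C(Nc1cccc(-n2cc(-c3ccncc3)c(-c3ccc(Cl)c(O)c3)n2)c1)Nc1cc(C(F)(F)F)cc(C(F)(F)F)c1` gives 896 nM. Compound 2 `COc1cc(-c2nn(-c3cccc(NC(=O)c4cccc(C(F)(F)F)c4)c3)cc2-c2ccncc2)ccc1Cl` gives 1830 nM, the highest of the three numbers; compound 2 and compound 1 stand within the scatter of each other, while compound 3 gives a lower number than compound 2 by a margin beyond the scatter. Compound 4 `COc1cc(-c2nn(-c3cccc(NC(=O)Nc4ccc(Cl)c(C(F)(F)F)c4)c3)cc2-c2ccncc2)ccc1Cl` has not yet been measured. It differs from compound 2 in a single place: (4-chloro-3-(trifluoromethyl)phenyl)amino in place of 3-(trifluoromethyl)phenyl on a carbonyl carbon. Compound 1 and compound 3 are built in the same way as compound 4 at that carbonyl carbon, and the result for compound 3 shows that this arrangement can go with a lower number. For the step from compound 2 to compound 4, a shift of a 1.8-fold lower number from compound 2 to compound 4 (0.26 log units; within the scatter) toward a lower number is expected, though not clearly beyond the scatter. Compound 4 is therefore estimated at 1000 nM, within a range from 400 nM to 2500 nM.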

Compound 4, concentration for 50% growth inhibition: 1200 nM
Compound 4: the middle estimate sits 1.2-fold (0.08 log units) below what was measured; the measured number falls inside the stated range.
By their numbers in this assay, from the lowest: compounds 3, 4, 1 and 2 (each within the scatter of the next, the first and the last beyond it).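

In this assay, going by these compounds alone, putting (4-chloro-3-(trifluoromethyl)phenyl)amino in place of 3-(trifluoromethyl)phenyl on a carbonyl carbon gives a 1.5-fold lower number from compound 2 to compound 4 (0.18 log units; within the scatter) and so provides the first direct one-place comparison at this position. The entering group adds a nitrogen, a chlorine and a hydrogen-bond donor in a single change, yet the step stays within the usual scatter of repeated measurements. At this position, then, the two groups cannot be told apart in this growth read-out, and this one step does not establish any gain from the change.

As far as these compounds go, it remains open how the amino link would read without the chloro group, or how a piperidine or a cyclohexyl group would read on this carbonyl carbon. Nothing available here accounts for the size of this step.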